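Fluorophenyl ether in a bromochromenone triazole series

The source may report more compounds than this note shows. Statements on the series, on what has been measured and on what is new or still open speak of the compounds shown alone.

Compound 2 `O=c1cc(-n2cc(COc3ccccc3O)nn2)c2cc(Br)ccc2o1` stands at the higher of the two numbers in a functional assay on MCF7 cells (Homo sapiens) for antiproliferative activity, read by MTT assay, with a stated time of 48 h (on this read-out lower numbers stand for stronger inhibition and higher numbers for weaker inhibition), with 24800 nM; compound 1 `O=c1cc(-n2cc(COc3ccccc3)nn2)c2cc(Br)ccc2o1` gives 1720 nM. Among the measured compounds shown here, the single step between them, a 14-fold higher number from compound 1 to compound 2 (1.16 log units; beyond the scatter), is the only one measured. Compound 3 `O=c1cc(-n2cc(COc3ccc(F)cc3)nn2)c2cc(Br)ccc2o1` differs from compound 2 by 4-fluorophenyl in place of 2-hydroxyphenyl on an oxygen on a saturated carbon. For the measured compounds named here, no measured step introduces a fluorine, so the only guide is the step from compound 1 to compound 2, which shows that the hydroxy accounts for a large part of the weaker number of compound 2. Removing it again is therefore expected to bring compound 3 back near compound 1, with the fluorine itself an open question. Compound 3 is estimated at 2000 nM, with a range of 700 nM to 7000 nM, a step of a 12-fold lower number from compound 2 to compound 3 (1.09 log units; beyond the scatter) expected beyond the scatter.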

Compound 3, half-maximal inhibitory concentration: 7000 nM
Estimate against measurement, compound 3: 3.5-fold (0.54 log units) below; low and high end bracket the measured number.
By their numbers in this assay, from the lowest: compound 1; then compound 3; then compound 2.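

Unsubstituted phenoxy remains the best of the three at this position: a fluoro in place of hydrogen on an aromatic carbon also weakens the read-out in this assay, with a 4.1-fold higher number from compound 1 to compound 3 (0.61 log units; beyond the scatter) as the step, so the hydroxy is not the only change on this ring that raises the number. Exchanging 2-hydroxyphenyl for 4-fluorophenyl gives a 3.5-fold lower number from compound 2 to compound 3 (0.55 log units; beyond the scatter) and so regains only part of the ground lost with the hydroxy, leaving compound 3 in the middle of the three. Nothing measured here explains either step.

The compounds shown leave open whether a chloro or a methoxy on the phenyl ring would give a number like that of compound 3. Because 2-hydroxyphenyl and 4-fluorophenyl differ in both substituent and placement, they also leave open how much placement on the ring contributes by itself.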